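Phenyl in place of methoxy on the thiourea tail

The compounds below may be only part of what the source reports. "The series", "measured", "known", "first", "only" and "open" are said of these compounds alone.

Compound 1 `NC(=S)Nc1cccc(OCCCCCOc2ccccc2)c1`: in an ADME assay on Ava5 cells (Homo sapiens) for cytotoxicity (on this read-out higher numbers stand for lower toxicity in this test and lower numbers for higher toxicity in this test), compound 1 gives > 50000 nM, a limit of the assay.
Compound 2 `NC(=S)Nc1cccc(OCCCCCOc2ccc(Br)cc2)c1`: in this assay compound 2 gives 19000 nM.
Compound 3 `COc1ccc(OCCCCCOc2cccc(NC(N)=S)c2)cc1`: in this assay compound 3 gives > 50000 nM, a limit of the assay.

Within the data shown here, compound 3 therefore stands only at a limit, as does compound 1, while compound 2 is the one compound with a read number. The step from compound 1 to compound 2 was an at least 2.6-fold lower number from compound 1 to compound 2 (0.42 log units; beyond the scatter), and that from compound 2 to compound 3 was an at least 2.6-fold higher number from compound 2 to compound 3 (0.42 log units; beyond the scatter); the step from compound 1 to compound 3 is a step that the two limits leave unreadable from compound 1 to compound 3, a consequence of the limit of > 50000 nM in this assay, at which 2 of the 3 values shown sit.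

Compound 4 `NC(=S)Nc1cccc(OCCCCCOc2ccc(-c3ccccc3)cc2)c1` differs from compound 3 by phenyl in place of methoxy on an aromatic carbon. Among the measured compounds shown here, the only readable steps are those around bromo, where a non-hydrogen group at this place lowered the number. On that basis the step from compound 3 to compound 4 is estimated as an at least 2.0-fold lower number from compound 3 to compound 4 (0.30 log units; that floor lies within the scatter), a modest fall. Compound 4 is thus expected to give about 25000 nM, between 8000 nM and 50000 nM, with a fair chance that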

Compound 4, half-maximal cytotoxic concentration: > 50000 nM
Compound 4 gave a limit, no number; the forecaster's own chance of this, stated with the estimate: 35%; middle value at least 2.0-fold (0.30 log units) away from the limit.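

Phenyl in place of bromo gives an at least 2.6-fold higher number from compound 2 to compound 4 (0.42 log units; beyond the scatter), so in this assay a group much larger than bromo at this place, with 6 heavy atoms and a six-membered aromatic ring, does not bring the number down. Among the four substituents shown, hydrogen, bromo, methoxy and phenyl, only bromo gives a read number, and the fall seen with bromo does not follow group size, with compound 4 going against any such trend. The steps from compound 3 to compound 4 and from compound 1 to compound 4 cannot be read: the limit of > 50000 nM in this assay, at which 3 of the 4 values shown sit.

From the compounds shown here alone, how far the true values of compound 1, compound 3 and compound 4 lie past that limit stays open. So does whether chloro, an amine or a carboxylic acid at this place would behave like bromo or like phenyl.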